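The source may report more compounds than this note shows. Statements on the series, on what has been measured and on what is new or still open speak of the compounds shown alone.

Measured so far:
compound 1, `CC1(C)[C@@H]2CC[C@@]1(CS(=O)(=O)N1CCN(c3cc(C(F)(F)F)ccn3)CC1)C(=O)C2`, 25100 nM
compound 2, `CC1(C)[C@@H]2CC[C@@]1(CS(=O)(=O)N1CCN(c3ncc(C(F)(F)F)cc3Cl)CC1)C(=O)C2`, 398 nM

Within the data shown here, in a functional assay on CHO-K1 cells for antagonist activity at C-X-C chemokine receptor type 3 (Homo sapiens), read by FLIPR and calcium flux (on this read-out higher numbers stand for weaker inhibition and lower numbers for stronger inhibition), compound 1 gives 25100 nM, the higher of the two numbers recorded, and its only neighbour in the set is compound 2, which gives 398 nM, a gap that lies beyond the usual scatter of repeated measurements. Compound 3, `CC1(C)[C@@H]2CC[C@@]1(CS(=O)(=O)N1CCN(c3cc4ccccc4cn3)CC1)C(=O)C2`, has not yet been measured in this assay. It keeps the shared core of compound 1 and differs from it in one place: isoquinolin-3-yl in place of 4-(trifluoromethyl)pyridin-2-yl on an amine nitrogen in a ring. Among the measured compounds shown here, no step between measured compounds matches this change, so nothing in the set directly shows what a fused second ring in this position does. The only measured variation at the same ring, from compound 1 to compound 2, shows that changes to the aromatic group on the amine nitrogen in a ring can move the number a great deal. The step from compound 1 to compound 3 is expected to be a moderate fall in the number, a 4.2-fold lower number from compound 1 to compound 3 (0.62 log units; beyond the scatter), with wide uncertainty in both directions. Compound 3 is therefore estimated at 6000 nM, within a range from 800 nM to 40000 nM.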

Compound 3, half-maximal inhibitory concentration: 15800 nM
Estimate against measurement, compound 3: 2.6-fold (0.42 log units) below; the range from low to high includes it.
By their numbers in this assay, from the lowest: compound 2; then compounds 3 and 1 (each within the scatter of the next).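

In this assay the exchange of 4-(trifluoromethyl)pyridin-2-yl for isoquinolin-3-yl on an amine nitrogen in a ring gives a step that cannot be told from repeat measurement (a 1.6-fold lower number from compound 1 to compound 3 (0.20 log units; within the scatter)). Among these compounds, the earlier compounds showed only that the number can differ widely among compounds with different aromatic groups at this place; this pair adds a first single-place comparison, and in it a fused ring of carbon takes the place of trifluoromethyl with no change that this assay can resolve. Nothing measured here accounts for this result, and the reading of these two groups as alike stays a plain observation for this one pair.

What sets compound 2 apart, at 398 nM in this assay, stays open: no compound shown differs from it in one place, so its value cannot be assigned to any single feature of its aromatic group. Also open, from the compounds shown here alone, is how this place would read with a plain phenyl ring, or with an aromatic ring carrying an amine or a carboxylic acid.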